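Ethyl to methoxy: a step with little support

The source may report more compounds than this note shows. Statements on the series, on what has been measured and on what is new or still open speak of the compounds shown alone.

Compound 1 `NC(=S)N/N=C(/COc1ccc(Br)cc1)c1ccc(F)cc1` gives < 26200 nM (a limit)
Compound 2 `NC(=S)N/N=C(/COc1ccc(Br)cc1)c1ccc(Cl)cc1` gives 25100 nM (a number)
Compound 3 `CCc1ccc(OC/C(=N\NC(N)=S)c2ccc(Br)cc2)cc1` gives < 25500 nM (a limit)

All three values come from an ADME assay on L929 cells (Mus musculus) for cytotoxicity, read by resazurin assay, with a stated time of 96 h (a higher number here means that more compound is tolerated, a lower number that less compound is tolerated), and describe how much compound the cells tolerate. Compound 3 offers only a limit (< 25500 nM) and no number, so the starting point of this step is not fixed. Compound 1 likewise offers only a limit (< 26200 nM).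

Compound 4 `COc1ccc(OC/C(=N\NC(N)=S)c2ccc(Br)cc2)cc1` is compound 3 with a single change: methoxy in place of ethyl on an aromatic carbon in which methoxy takes the place of ethyl on an aromatic carbon. Going by the values given here, the only measured pair that differs in one place gives a step that the limit leaves unreadable from compound 1 to compound 2 for chloro in place of fluoro on an aromatic carbon. That is another change, and it supplies no size to carry over. Among the compounds with values here, the one firm number nearby belongs to compound 2 (25100 nM), and the expectation leans on it. No direction can be argued in this assay from these data, so no step beyond the scatter is expected. The estimate amounts to a step that the limit leaves unreadable from compound 3 to compound 4 as the expected step. For compound 4 the estimated value is 22000 nM with an expected range from 10000 nM to 45000 nM and a good chance of ending up with only a limit.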

Compound 4, half-maximal cytotoxic concentration: 102000 nM
Compound 4: the middle estimate sits 4.6-fold (0.67 log units) below what was measured, outside the stated range (above it).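

In this assay, methoxy in place of ethyl on an aromatic carbon, para to a large group, gives an at least 4.0-fold higher number from compound 3 to compound 4 (0.60 log units; beyond the scatter). Going by these compounds alone, this is the first step that can be read, since the only earlier one, chloro in place of fluoro, cannot be read; it shows that cell tolerance responds to the group at this position, even though both groups have the same number of heavy atoms and differ in that methoxy has an oxygen where ethyl has a carbon. The true step may be larger than the printed figure because the starting point is only a limit for compound 3: the limit of < 25500 nM in this assay, at which 1 of the 4 values shown sits.

A single pair cannot tell whether the oxygen itself, or the hydrogen-bond acceptor counted for methoxy, lies behind the step, and it cannot show whether a hydroxyl group, an amine or a longer chain such as ethoxy at the same place would behave in the same way. It also leaves open whether the same exchange would give a step of similar size on the core of compound 1 or compound 2.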